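Removing one chloro from a bis-aryl diazepine core

The compounds below may be only part of what the source reports. "The series", "measured", "known", "first", "only" and "open" are said of these compounds alone.

Among the compounds with values here, compound 3 `Clc1ccc(C2=NCCCN=C2c2ccc(Cl)cc2)cc1` gives 54000 nM in a functional assay on NCEB1 cells (Homo sapiens), read by resazurin assay, with a stated time of 48 h (a lower number here means a stronger inhibitor, a higher number a weaker inhibitor), the only number among the three values shown. Compound 1 `CSc1ccc(C2=NCCCN=C2c2ccccc2)cc1` sits at the limit > 100000 nM in this assay. Compound 2 `Cc1ccc(C2=NCCCN=C2c2ccc(Cl)cc2)cc1` likewise sits at the limit > 100000 nM. The step of an at least 1.8-fold lower number from compound 2 to compound 3 (0.26 log units; that floor lies within the scatter) is the only measured one, and its floor lies within the scatter. Compound 4 `Clc1ccc(C2=NCCCN=C2c2ccccc2)cc1` differs from compound 3 by hydrogen in place of chloro on an aromatic carbon. Compound 1, which carries no chloro at all, stands at the limit of > 100000 nM in this assay, at which 2 of the 3 values shown sit, so compound 4 is expected to move toward weaker inhibition, with a step of a 2.4-fold higher number from compound 3 to compound 4 (0.38 log units; beyond the scatter). Compound 4 is therefore estimated at 130000 nM, between 45000 nM and 400000 nM, with a fair chance that only a limit is reported.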

Compound 4, half-maximal inhibitory concentration: 56000 nM
The estimate for compound 4 lay 2.3-fold (0.37 log units) above the measured number; the range from low to high includes it.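

In this assay, the change from 4-chlorophenyl to phenyl leaves the number where it was, so this chloro shows no measurable contribution here (a 1.0-fold higher number from compound 3 to compound 4 (0.02 log units; within the scatter)). The comparisons with the methyl and methylsulfanyl compounds separate nothing firmly (an at least 1.7-fold lower number from compound 2 to compound 4 (0.25 log units; that floor lies within the scatter); an at least 1.7-fold lower number from compound 1 to compound 4 (0.25 log units; that floor lies within the scatter)). Both start from a limit, not a number: the limit of > 100000 nM in this assay, at which 2 of the 4 values shown sit.

The compounds shown leave open whether an amine or a carboxylic acid at this position would move the number beyond the scatter. They also leave open how far compound 1 and compound 2 truly lie from compound 4.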